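The source may report more compounds than this note shows. Statements on the series, on what has been measured and on what is new or still open speak of the compounds shown alone.

In an ADME assay on CHO cells (Cricetulus griseus) for cytotoxicity, read by MTT assay (on this read-out lower numbers stand for stronger inhibition and higher numbers for weaker inhibition), compound 3 `Cc1cc(C2CC2)n(-c2nc(C(F)(F)F)cc(=O)[nH]2)n1` gives 78000 nM, the highest of the two numbers recorded there. Compound 1 `Cc1cc(C)n(-c2cc(-c3ccccc3)nc(=O)[nH]2)n1` gives 10000 nM in this assay, a lower number than compound 3 and beyond the usual scatter. Compound 2 `Cc1cc(C)n(-c2nc(-c3ccc(F)cc3)c(C(=O)O)c(=O)[nH]2)n1` reaches only a limit of this assay, > 50000 nM; (the limit of > 50000 nM in this assay, at which 1 of the 3 values shown sits). Compound 4 `Cc1cc(Nc2ccccn2)n(-c2nc(C(F)(F)F)cc(=O)[nH]2)n1` has not yet been measured in this assay; it differs from compound 3 by (pyridin-2-yl)amino in place of cyclopropyl on an aromatic carbon. For the measured compounds named here, no two measured compounds differ in only one place, so no measured step points the way. The expectation is that the change from compound 3 to compound 4 moves this assay little, with a step of a 1.3-fold lower number from compound 3 to compound 4 (0.11 log units; within the scatter), none beyond the scatter. Compound 4 is therefore estimated at 60000 nM, between 20000 nM and 150000 nM.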

Compound 4, half-maximal inhibitory concentration: 23000 nM
Estimate against measurement, compound 4: 2.6-fold (0.42 log units) above, and the stated range covers the measured number.
By their numbers in this assay, from the lowest: compound 1; then compound 4; then compound 3.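

In this assay the aromatic carbon next to the ring nitrogen responds to its substituent: (pyridin-2-yl)amino in place of cyclopropyl gives a 3.4-fold lower number from compound 3 to compound 4 (0.53 log units; beyond the scatter) in the only single-place comparison shown, a modest step beyond the scatter. This position is therefore not silent on this read-out. Nothing measured here accounts for the size of this step. The compounds shown leave open whether the linking amino nitrogen or the pyridin-2-yl ring carries the step. A plain amine or a phenylamino group on this carbon would separate the two.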